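Thiourea Replaces a Fluorobenzyl on the Ring Nitrogen

The source may report more compounds than this note shows. Statements on the series, on what has been measured and on what is new or still open speak of the compounds shown alone.

Of the compounds shown here, three sharing one core have been tested in a functional assay on HeLa cells (Homo sapiens) for antiproliferative activity, with a stated time of 24 h; a lower number here means a stronger inhibitor, a higher number a weaker inhibitor. Compound 1 `NC(=O)c1c(NC(=O)c2ccccc2Cl)sc2c1CCN(Cc1ccccc1F)C2` reaches only a limit of the assay, giving > 50000 nM in this assay. Compound 2 `NC(=O)c1c(NC(=O)c2ccccc2Cl)sc2c1CCN(Cc1ccc(Cl)cc1)C2` likewise reaches only a limit, giving > 50000 nM in this assay. For the measured compounds named here, compound 3 `NC(=O)c1c(NC(=O)c2cccc([N+](=O)[O-])c2)sc2c1CCN(Cc1c(Cl)cccc1Cl)C2` is the one compound with a number, giving 46100 nM in this assay. Compound 1 thus stands at the limit of > 50000 nM in this assay, at which 2 of the 3 values shown sit, so its standing among the others cannot be read more closely. Going by the values given here, the only measured step, a step that the two limits leave unreadable from compound 1 to compound 2, also swaps the group on the amine nitrogen in the ring, but its size is not readable.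

Compound 4 `COc1ccc(NC(=S)N2CCc3c(sc(NC(=O)c4ccccc4Cl)c3C(N)=O)C2)cc1` differs from compound 1 by a group of 11 heavy atoms (8 carbon, 1 nitrogen, 1 oxygen, 1 sulfur; one six-membered aromatic ring of carbon only) in place of a group of 8 heavy atoms (7 carbon, 1 fluorine; one six-membered aromatic ring of carbon only), on an amine nitrogen in a ring. Among the compounds with values here, no measured step tells what this change does. Compound 4 is expected to stay weak because compound 1 gives only the limit > 50000 nM. The expected step of an at least 1.2-fold lower number from compound 1 to compound 4 (0.09 log units; that floor lies within the scatter) is estimated as no change beyond the scatter. The estimate for compound 4 is 40000 nM, with a range from 12000 nM to 50000 nM.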

Compound 4, half-maximal inhibitory concentration: 36400 nM
Estimate against measurement, compound 4: 1.1-fold (0.04 log units) above; the range from low to high includes it.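

In this assay, for the compounds shown here, compound 4 gives 36400 nM, so among the compounds that differ from compound 1 only on the amine nitrogen in a ring, it is the one with a number rather than a limit. The change to the thiourea-bearing group gives an at least 1.3-fold lower number from compound 1 to compound 4 (0.13 log units; that floor lies within the scatter) and an at least 1.3-fold lower number from compound 2 to compound 4 (0.13 log units; that floor lies within the scatter), so neither step shows a gain beyond the scatter. Both steps are only floors, not true sizes, because the compounds they start from stand at a limit of the assay: the limit of > 50000 nM in this assay, at which 2 of the 4 values shown sit.

The compounds shown leave open whether the thiourea sulfur or the methoxy group matters here, and a urea, with oxygen in place of that sulfur, would address the first point. Going by these compounds, it also remains open how a carboxylic acid or a longer chain on this nitrogen would read in this assay.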